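The source may hold more compounds than are shown below. What is called first, only, known or untested is meant among the compounds shown, and "the series" means these compounds.

Measured so far:
Compound 1 `O=C1NC[C@@H](c2c[nH]c3cc(Br)ccc23)N=C1c1c[nH]c2ccccc12`, in an ADME assay on A549 cells (Homo sapiens) for cytotoxicity (on this read-out higher numbers stand for an effect only at larger amounts of compound and lower numbers for an effect already at smaller amounts), compound 1 gives 3.71 ug/mL.
Compound 2 `O=C1NC[C@@H](c2c[nH]c3ccccc23)N=C1c1c[nH]c2ccccc12`, in which compound 2 gives 11.7 ug/mL.
Compound 3 `O=C(C1=NC(c2c[nH]c3ccccc23)CN1)c1c[nH]c2cc(Br)ccc12`, for which compound 3 gives only a limit of the assay, > 30 ug/mL.

Compound 1 and compound 2 share a core, and the change between them is bromo in place of hydrogen on an aromatic carbon. That change gave a 3.2-fold lower number from compound 2 to compound 1 (0.50 log units; beyond the scatter). The difference between the core of compound 2 and the core of compound 3 is not broken down here. Compound 4 `O=C(C1=NC(c2c[nH]c3cc(Br)ccc23)CN1)c1c[nH]c2cc(Br)ccc12` is not yet measured. Compound 4 differs from compound 3 by bromo in place of hydrogen on an aromatic carbon, the same change as from compound 2 to compound 1, at a place described in the same words. The starting point is less firm, since compound 3 sits at the limit of > 30 ug/mL in this assay, at which 1 of the 3 values shown sits. The step is expected to be an at least 1.5-fold lower number from compound 3 to compound 4 (0.17 log units; that floor lies within the scatter), resting on the step from compound 2 to compound 1. Compound 4 is thus estimated at 20 ug/mL, between 8 ug/mL and 60 ug/mL.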

Compound 4, concentration for half-maximal effect: 5.22 ug/mL
Compound 4: the middle estimate sits 3.8-fold (0.58 log units) above what was measured; measured number below the stated range.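

Bromo in place of hydrogen on an aromatic carbon gives an at least 5.7-fold lower number from compound 3 to compound 4 (0.75 log units; beyond the scatter) and, on the other core, a 3.2-fold lower number from compound 2 to compound 1 (0.50 log units; beyond the scatter) in this assay, so the direction of the change carried over between these two cores.
Whether the size carried over as well stays unsettled: the same change on two cores in this assay, a 3.2-fold lower number (0.50 log units; beyond the scatter) from compound 2 to compound 1 and an at least 5.7-fold lower number (0.75 log units; beyond the scatter) from compound 3 to compound 4; the limit leaves it open whether they differ
Two cores show that the change can behave alike in this series, but they do not make a rule for any other core.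

The compounds shown leave open whether chloro, methoxy or an amine on the same aromatic carbon would move the number in the same direction as bromo. They also leave open how bromo would behave on any other aromatic carbon of these cores.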